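A few compounds are considered here, and "the series" means these few. Any claim that something is new, unique, unknown or untested is made for them only; others in the source may bear on it.

Measured in an ADME assay on L02 cells (Homo sapiens) for cytotoxicity, read by MTT assay, with a stated time of 72 h; a higher number here means a weaker inhibitor, a lower number a stronger inhibitor:
- compound 1 `C=CC(=O)Nc1cccc(Oc2nc(Nc3ccn(C)n3)nc3c2CSCC3)c1`: > 50000 nM (a limit, not a number)
- compound 2 `C/C=C/C(=O)Nc1cccc(Oc2nc(Nc3ccn(C)n3)nc3c2CSCC3)c1`: > 50000 nM (a limit, not a number)
- compound 3 `C=CC(=O)Nc1cccc(Oc2nc(Nc3cccc(OC)c3)nc3c2CSCC3)c1`: 48900 nM

Of these three, compound 3 alone gives an actual number, 48900 nM. The rest of the picture is the limit of > 50000 nM in this assay, at which 2 of the 3 values shown sit.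

Compound 4 `C/C=C/C(=O)Nc1cccc(Oc2nc(Nc3cccc(OC)c3)nc3c2CSCC3)c1` differs from compound 3 in one place, on a carbonyl carbon: prop-1-en-1-yl in place of vinyl on a carbonyl carbon. The same exchange has been measured once, as a step that the two limits leave unreadable from compound 1 to compound 2, so it offers a precedent but no size. The other measured step, an at least 1.0-fold lower number from compound 1 to compound 3 (0.00 log units; that floor lies within the scatter), involves a different part of the molecule and shows no change beyond the scatter. With no readable step pointing either way, no shift beyond the scatter is expected in this assay. The expected step is a 1.0-fold higher number from compound 3 to compound 4 (0.01 log units; within the scatter). A reading at the limit of the assay would be no surprise. For compound 4 the estimated value is 50000 nM, with an expected range of 25000 nM to 100000 nM.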

Compound 4, half-maximal inhibitory concentration: > 50000 nM
Compound 4 ended at the assay's limit; the forecaster's own chance of this, stated with the estimate: 55%; the middle value sits exactly at the limit.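

In this assay, the exchange of vinyl for prop-1-en-1-yl on the carbonyl carbon can now be set against a real starting number, and it gives an at least 1.0-fold higher number from compound 3 to compound 4 (0.00 log units; that floor lies within the scatter). The same exchange from compound 1 to compound 2 and the step from compound 2 to compound 4 cannot be read, as both ends of each are limits rather than numbers. Compound 2 and compound 4, which carry the prop-1-en-1-yl group with different groups on the aromatic amine nitrogen, therefore share the same ceiling, and most of this small set now rests there: the limit of > 50000 nM in this assay, at which 3 of the 4 values shown sit.

From the compounds shown here alone, how far past that limit compound 1, compound 2 and compound 4 lie stays open. Also open, going by these compounds, is whether a longer chain, or a chain ending in an amine, on the same carbonyl carbon would give a clearly lower number in this assay.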